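This account rests on a few compounds, and the source may have more. Where it says the series, first, only, none or still open, it means among the compounds named here.

The three measured compounds share one core and differ only in the group carried on an aromatic carbon of the five-membered ring: compound 1 `C=Cc1ccsc1CN[C@@H]1C[C@H]2C[C@@H]([C@H]1C)C2(C)C` bears vinyl, compound 2 `C[C@H]1[C@H](NCc2sccc2-c2ccsc2)C[C@H]2C[C@@H]1C2(C)C` thiophen-3-yl and compound 3 `CCOc1ccsc1CN[C@@H]1C[C@H]2C[C@@H]([C@H]1C)C2(C)C` ethoxy. In an ADME assay on MDCK cells (Canis lupus familiaris) for cytotoxicity, read by microscopy, with a stated time of 48 h (on this read-out higher numbers stand for lower toxicity in this test and lower numbers for higher toxicity in this test), compound 1 gives 50000 nM. In this assay compound 2 gives 12500 nM. In this assay compound 3 gives 50000 nM. Within the data shown here, compound 3 therefore stands level with compound 1, the two together at the top of the three numbers; the only step beyond the scatter in the set is a 4.0-fold higher number from compound 2 to compound 3 (0.60 log units; beyond the scatter).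

Compound 4 `CCCCc1ccsc1CN[C@@H]1C[C@H]2C[C@@H]([C@H]1C)C2(C)C` carries butyl in place of ethoxy on an aromatic carbon. Among the measured compounds shown here, no measured step exchanges ethoxy for a plain carbon chain. The nearest precedents are no change at the digits printed from compound 1 to compound 3 (within the scatter), where one small group replaced another at the same aromatic carbon with no change, and a 4.0-fold lower number from compound 1 to compound 2 (0.60 log units; beyond the scatter), where a ring entering there gave a modest drop. Butyl is a chain rather than a ring, so the first precedent is the closer guide; a step in this assay within the scatter is expected, with a slight lean toward a lower number. Compound 4 is expected to give 35000 nM in this assay, with a range of 12500 nM to 50000 nM. The estimated step is a 1.4-fold lower number from compound 3 to compound 4 (0.15 log units; within the scatter).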

Compound 4, minimum cytotoxic concentration: 25000 nM
Compound 4: the middle estimate sits 1.4-fold (0.15 log units) above what was measured; the measured number falls inside the stated range.
By their numbers in this assay, from the lowest: compounds 2, 4, 1 and 3 (each within the scatter of the next, the first and the last beyond it).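

In this assay, butyl on this aromatic carbon gives a 2.0-fold lower number from compound 3 to compound 4 (0.30 log units; within the scatter), so replacing ethoxy with a carbon chain that has no hydrogen-bond acceptor does not carry the number beyond the scatter. The chain also gives a 2.0-fold lower number from compound 1 to compound 4 (0.30 log units; within the scatter) and a 2.0-fold higher number from compound 2 to compound 4 (0.30 log units; within the scatter), which places compound 4 within the scatter of all three earlier compounds, even though the step of a 4.0-fold higher number from compound 2 to compound 3 (0.60 log units; beyond the scatter) lies beyond it, so the butyl result does not align this group with either end of the set. Among these compounds, nothing available here explains these steps or the one step beyond the scatter.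

The compounds shown leave open whether a longer chain such as octyl, or a chain ending in an amine or a carboxylic acid, would stay within the scatter of compound 4 in this assay or move beyond it. They also leave open whether a saturated ring such as cyclohexyl on this carbon would match the step seen with thiophen-3-yl or stay level with the chain and ethoxy.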